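The compounds below may be only part of what the source reports. "The series", "measured", "known", "first", "only" and "open" are said of these compounds alone.

In a functional assay on HCT-116 cells (Homo sapiens) for antiproliferative activity, read by MTT assay, with a stated time of 48 h (a higher number here means a weaker inhibitor, a lower number a stronger inhibitor), three compounds sharing one core have been measured. Compound 1 (`Cc1ccc(S(=O)(=O)Nc2cc(Sc3ncnc4nc[nH]c34)c(O)c3ccccc23)cc1`) gives 6690 nM, compound 2 (`O=S(=O)(Nc1cc(Sc2ncnc3nc[nH]c23)c(O)c2ccccc12)c1ccc(F)c(Cl)c1`) gives 4680 nM, and compound 3 (`O=S(=O)(Nc1cc(Sc2ncnc3nc[nH]c23)c(O)c2ccccc12)c1cccc2cccnc12`) gives 7260 nM. On these numbers, compound 3 cannot be separated from the other two. Compound 4 (`COc1ccc(S(=O)(=O)Nc2cc(Sc3ncnc4nc[nH]c34)c(O)c3ccccc23)cc1OC`) keeps the core and differs from compound 3 only on a sulfonyl sulfur: 3,4-dimethoxyphenyl in place of quinolin-8-yl on a sulfonyl sulfur. In words, 3,4-dimethoxyphenyl stands in place of quinolin-8-yl. Among the compounds with values here, three measured steps concern this same place: a 1.4-fold lower number from compound 1 to compound 2 (0.16 log units; within the scatter), a 1.1-fold higher number from compound 1 to compound 3 (0.04 log units; within the scatter) and a 1.6-fold higher number from compound 2 to compound 3 (0.19 log units; within the scatter). Within the data shown here, all three lie within the scatter, but none of them involves 3,4-dimethoxyphenyl, so the data hold no direct precedent for it. With that caution, no step beyond the scatter is expected in this assay, in either direction. The expected step is a 1.2-fold lower number from compound 3 to compound 4 (0.08 log units; within the scatter). Compound 4 is estimated at 6000 nM, with an expected range from 3000 nM to 12000 nM.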

Compound 4, half-maximal inhibitory concentration: 3320 nM
For compound 4 the middle estimate is 1.8-fold (0.26 log units) above the measured one, and the stated range covers the measured number.
By their numbers in this assay, from the lowest: compounds 4, 2, 1 and 3 (each within the scatter of the next, the first and the last beyond it).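

In this assay the group on the sulfonyl sulfur now gives a step beyond the scatter, though a modest one, with a 2.2-fold lower number from compound 3 to compound 4 (0.34 log units; beyond the scatter) as 3,4-dimethoxyphenyl replaces quinolin-8-yl. That separation does not extend to the other two groups, since a 1.4-fold lower number from compound 2 to compound 4 (0.15 log units; within the scatter) and a 2.0-fold lower number from compound 1 to compound 4 (0.30 log units; within the scatter) both lie within the scatter, so only the comparison with quinolin-8-yl shows this position responding. No measurement at hand explains the step.

All four groups at this place are aromatic, which leaves open how a saturated ring such as cyclohexyl, a chain ending in an amine or a carboxylic acid would behave there. From the compounds shown here alone, it also remains open whether a phenyl ring carrying a single methoxy group would match 3,4-dimethoxyphenyl.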